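Working notes on compound 4 in the cytotoxicity test

The source may report more compounds than this note shows. Statements on the series, on what has been measured and on what is new or still open speak of the compounds shown alone.

Measured compounds:
compound 1 `O=[N+]([O-])c1c(CS(=O)(=O)c2ccccc2)nc2c(-c3ccccc3)cc(Cl)cn12` gives in an ADME assay on HepG2 cells (Homo sapiens) for cytotoxicity, read by MTT assay, with a stated time of 72 h; on this read-out higher numbers stand for lower toxicity in this test and lower numbers for higher toxicity in this test > 15600 nM, which is a limit of the assay and not a number.
compound 2 `CCN(CC)c1ccc(-c2cc(Cl)cn3c([N+](=O)[O-])c(CS(=O)(=O)c4ccccc4)nc23)cc1` gives in this assay > 15600 nM, again a limit.
compound 3 `O=Cc1ccc(-c2cc(Cl)cn3c([N+](=O)[O-])c(CS(=O)(=O)c4ccccc4)nc23)cc1` gives in this assay > 31200 nM, also a limit.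

Compound 2 therefore stands nowhere in particular among these three: every value is a limit, two of them at the limit of > 15600 nM in this assay, at which 2 of the 3 values shown sit, and one at the limit of > 31200 nM in this assay, at which 1 of the 3 values shown sits, so no compound can be ranked against another.

The change to compound 4 `O=[N+]([O-])c1c(CS(=O)(=O)c2ccccc2)nc2c(-c3ccc(O)cc3)cc(Cl)cn12` is hydroxy in place of diethylamino on an aromatic carbon. Within the data shown here, two measured steps touch the same place. The step from compound 1 to compound 2 a step that the two limits leave unreadable from compound 1 to compound 2 brought the diethylamino group in, and the step from compound 2 to compound 3 a step that the two limits leave unreadable from compound 2 to compound 3 took it out again for formyl; neither has a readable size, as both ends are limits. The step from compound 1 to compound 3 a step that the two limits leave unreadable from compound 1 to compound 3 is unreadable for the same reason. Nothing seen so far points to any step in this assay beyond the scatter, in either direction. The expected step is a step that the limit leaves unreadable from compound 2 to compound 4, that is, none beyond the scatter.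

Compound 4 is accordingly estimated at 20000 nM in this assay, with a range from 10000 nM to 40000 nM, and will most probably be reported as a limit once more.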

Compound 4, half-maximal cytotoxic concentration: > 12500 nM
Compound 4 gave a limit, no number; the forecaster's own chance of this, stated with the estimate: 80%; the middle value does not contradict the limit.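

In this assay compound 4 gives > 12500 nM, a limit of the assay and not a number. Among these compounds, all four values are limits, and no step from compound 1, compound 2 or compound 3 to compound 4 can be read. The compounds shown leave open at what concentration any of them becomes cytotoxic, and how they rank against each other.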